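A few compounds are considered here, and "the series" means these few. Any claim that something is new, unique, unknown or untested is made for them only; others in the source may bear on it.

In a functional assay on HT-1080 cells (Homo sapiens) for cytotoxicity, read by MTT assay, with a stated time of 72 h (a higher number here means a weaker inhibitor, a lower number a stronger inhibitor), compound 1 (`COc1cccc(/C=C2\CCC/C(=C\c3cc(OC)c(OC)c(OC)c3)C2=O)c1OC`) gives 2300 nM and compound 2 (`COc1ccc(/C=C2\CCC/C(=C\c3ccccc3Br)C2=O)cc1OC`) gives 8400 nM as the higher of the two numbers, a gap beyond the scatter. Compound 3 (`COc1ccc(/C=C2\CCC/C(=C\c3ccc(OC)c(OC)c3)C2=O)cc1`), not yet measured, puts 4-methoxyphenyl in place of 2-bromophenyl (4-methoxyphenyl in place of 2-bromophenyl on a double-bonded chain carbon bound to a double-bonded ring carbon) on a double-bonded chain carbon bound to a double-bonded ring carbon. Within the data shown here, no measured single-place step exists in this assay to size this change. Compound 1, without bromine, stands at 2300 nM on the lower side, so a moderate fall in the number is expected. The estimated move is a 2.4-fold lower number from compound 2 to compound 3 (0.38 log units; beyond the scatter) in size. Compound 3 is expected at 3500 nM with an estimated range from 1000 nM to 12000 nM for now.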

Compound 3, half-maximal inhibitory concentration: 7200 nM
The estimate for compound 3 lay 2.1-fold (0.31 log units) below the measured number, within the range that was stated.
By their numbers in this assay, from the lowest: compound 1; then compounds 3 and 2 (each within the scatter of the next).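

In this assay, among these compounds, 4-methoxyphenyl in place of 2-bromophenyl on a double-bonded chain carbon bound to a double-bonded ring carbon gives a 1.2-fold lower number from compound 2 to compound 3 (0.07 log units; within the scatter), the first single-place step. At this position, the two aryl groups therefore cannot be told apart in this read-out. No other measurement bears on this result.

Going by these compounds, whether an amine or a carboxylic acid at this position would shift the number remains open. So does whether 4-bromophenyl would read the same as 2-bromophenyl.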